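The source may report more compounds than this note shows. Statements on the series, on what has been measured and on what is new or still open speak of the compounds shown alone.

In an in vitro ADME assay on microsomes from liver (Homo sapiens) for pharmacokinetics, read by LC-MS, with a stated time of 10 min, tested at 1 uM (on this read-out lower numbers stand for slow clearance and higher numbers for fast clearance), compound 1 `CN1C[C@H](C(=O)Nc2ccc(C3CC3)cc2)[C@@H](c2ccc(/C=C/C(=O)Nc3ccccc3N)cc2)C1` gives 12 mL/min/kg and compound 2 `CN1C[C@H](C(=O)Nc2ccc(Cl)cc2F)[C@@H](c2ccc(/C=C/C(=O)Nc3ccccc3N)cc2)C1` gives 11 mL/min/kg. Among the compounds with values here, compound 2 therefore stands level with compound 1, the only other measured compound. Within the data shown here, the one measured step, a 1.1-fold lower number from compound 1 to compound 2 (0.04 log units; within the scatter), lies within the scatter.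

Compound 3 `CN1C[C@H](C(=O)Nc2ccccn2)[C@@H](c2ccc(/C=C/C(=O)Nc3ccccc3N)cc2)C1` has pyridin-2-yl in place of 4-chloro-2-fluorophenyl on an amide-type nitrogen. Among the measured compounds shown here, the measured step is an exchange at the same nitrogen, but no measured compound carries pyridin-2-yl, so it offers only indirect guidance. Given that step of a 1.1-fold lower number from compound 1 to compound 2 (0.04 log units; within the scatter), no shift beyond the scatter is expected in this assay, in either direction. The expected step is a 1.1-fold lower number from compound 2 to compound 3 (0.04 log units; within the scatter).

For compound 3, the estimated clearance is 10 mL/min/kg, with an expected range of 5 mL/min/kg to 21 mL/min/kg.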

Compound 3, clearance: 8 mL/min/kg
Compound 3: middle estimate off by 1.3-fold (0.10 log units), on the high side, and the stated range covers the measured number.
By their numbers in this assay, from the lowest: compounds 3, 2 and 1 (each within the scatter of the next).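

In this assay, the exchange to pyridin-2-yl gives a 1.4-fold lower number from compound 2 to compound 3 (0.14 log units; within the scatter) and a 1.5-fold lower number from compound 1 to compound 3 (0.18 log units; within the scatter). The amide-type nitrogen therefore carries 4-cyclopropylphenyl, 4-chloro-2-fluorophenyl and pyridin-2-yl with no step beyond the scatter, so a ring with 1 hetero atom and 1 hydrogen-bond acceptor fits the flat picture that the two carbon-only rings gave. Nothing on hand explains these numbers.

Still open, going by these compounds, is whether a group of another kind on this nitrogen, such as a saturated chain ending in an amine or a carboxylic acid, would give a step beyond the scatter. Also open, on these data alone, is whether the flat picture at this nitrogen holds once the shared core is changed elsewhere.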